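Amino in place of the nitrobenzylidene imine on the shared core

The source may report more compounds than this note shows. Statements on the series, on what has been measured and on what is new or still open speak of the compounds shown alone.

Compound 1 `CCOC(=O)C(=O)NC1=C(C#N)C2C(N3CCCC3)CCCCN2C(=O)N1c1ccccc1` gives 81.6% in a functional assay on the whole organism (strain albino) for inhibition, with Rattus norvegicus as the target, read by paw edema, with stated times of 1 h and 3 h, at a dose of 18 mmol/kg by the intraperitoneal route; on this read-out higher numbers stand for a stronger effect at the one dose given and lower numbers for a weaker effect. Compound 2 `N#CC1=C(/N=C/c2ccc([N+](=O)[O-])cc2)N(c2ccccc2)C(=O)N2CCCCC(N3CCCC3)C12` gives 81.3% in this assay; compound 2 and compound 1 stand together within the scatter, as a number 0.3 percentage points lower from compound 1 to compound 2 (within the scatter) shows. Compound 3 `N#CC1=C(N)N(c2ccccc2)C(=O)N2CCCCC(N3CCCC3)C12` differs from compound 2 by one nitrogen atom in place of a group of 11 heavy atoms (7 carbon, 2 nitrogen, 2 oxygen; one six-membered aromatic ring of carbon only), on a double-bonded ring carbon. Within the data shown here, the only measured step, a number 0.3 percentage points lower from compound 1 to compound 2 (within the scatter), swapped one sizeable group for another at this same place without moving the read-out beyond the scatter. Among the measured compounds shown here, no measured step replaces such a group with amino; the size of that step is unknown. For compound 3 the expected step is a number 6.3 percentage points lower from compound 2 to compound 3 (within the scatter), with a wide range. Compound 3 is estimated at 75%, between 55% and 90%.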

Compound 3, a percentage reported as inhibition, in the whole organism at one dose (the size of the read-out at that dose, not a potency): 79.5%
Estimate against measurement, compound 3: 4.5 percentage points below; the measured number falls inside the stated range.
By their numbers in this assay, from the lowest: compounds 3, 2 and 1 (each within the scatter of the next).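

Amino on the double-bonded ring carbon gives a number 1.8 percentage points lower from compound 2 to compound 3 (within the scatter) in this assay, and hydrogen in place of (ethoxycarbonyl)carbonyl on the amine nitrogen gives a number 2.1 percentage points lower from compound 1 to compound 3 (within the scatter). The free amino thus stands level with both larger groups, so neither is required here for the effect at this one dose. Nothing available accounts for this lack of separation.

From the compounds shown here alone, whether it would hold with methyl on the amino nitrogen, or with a carboxylic acid in place of the cyano group, stays open. Potency also stays open, since the read-out comes from a single dose.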